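A few compounds are considered here, and "the series" means these few. Any claim that something is new, unique, unknown or untested is made for them only; others in the source may bear on it.

In a functional assay on HUVEC cells (Homo sapiens) for antiproliferative activity, read by MTT assay, with a stated time of 24 h (on this read-out lower numbers stand for stronger inhibition and higher numbers for weaker inhibition), compound 1 (`COc1cccc(C(=O)Oc2ccc3c(=O)c(-c4cc(OC)c(OC)cc4OC)coc3c2)c1`) reads > 10000 nM as a limit of the assay. Compound 2 (`COc1cc(OC)c(-c2coc3cc(OCc4ccc(Br)cc4)ccc3c2=O)cc1OC`) reads > 10000 nM as a limit too. Compound 3 (`COc1cc(OC)c(-c2coc3cc(OCc4ccc([N+](=O)[O-])cc4)ccc3c2=O)cc1OC`) also reads > 10000 nM as a limit and gives no number, so it stands level with the other two only in that none of them yields a value. Compound 4 (`COc1cc(OC)c(-c2coc3cc(OCc4cccc(Cl)c4)ccc3c2=O)cc1OC`) has not yet been measured. It changes one group on the saturated chain carbon bound to an oxygen on an aromatic ring, with 3-chlorophenyl in place of 4-nitrophenyl (3-chlorophenyl in place of 4-nitrophenyl on a saturated chain carbon bound to an oxygen on an aromatic ring). The measured change closest to this one is a step that the two limits leave unreadable from compound 2 to compound 3 with nitro in place of bromo. The other two changes, a step that the two limits leave unreadable from compound 1 to compound 2 and a step that the two limits leave unreadable from compound 1 to compound 3 as well, replace the (3-methoxyphenyl)carbonyl group. None of these steps has a size that could be carried over. Because of the limit of > 10000 nM in this assay, at which 3 of the 3 values shown sit, the expectation is that the new group brings no step beyond the scatter in either direction. The expected change is a step that the limit leaves unreadable from compound 3 to compound 4 and this remains an estimate. For compound 4 the estimated value is 15000 nM with an expected range from 6000 nM to 40000 nM and the assay may well report only a limit again.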

Compound 4, half-maximal inhibitory concentration: > 10000 nM
Compound 4: no number, only a limit; the forecaster's own chance of this, stated with the estimate: 85%; the middle value is on the limit's open side.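

In this assay compound 4 gives > 10000 nM as a limit and not a number. Its steps from compound 1, compound 2 and compound 3 cannot be read, because all four compounds sit at the same limit: the limit of > 10000 nM in this assay, at which 4 of the 4 values shown sit.

The compounds shown leave open how strongly any of them inhibits and whether exchanging these groups changes that at all.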